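The source may report more compounds than this note shows. Statements on the series, on what has been measured and on what is new or still open speak of the compounds shown alone.

Three nucleoside analogues built on one shared core have been tested in a functional assay on HepG2 cells (Homo sapiens) for antiproliferative activity, read by XTT assay, with a stated time of 72 h; on this read-out higher numbers stand for weaker inhibition and lower numbers for stronger inhibition. Compound 1, `COc1ncnc2c1c(-c1ccsc1)cn2[C@@H]1O[C@H](CO)[C@@H](O)[C@H]1O`, carries a thiophen-3-yl group, and in this assay compound 1 gives 430 nM. Compound 2, `COc1ncnc2c1c(-c1cccs1)cn2[C@@H]1O[C@H](CO)[C@@H](O)[C@H]1O`, differs from it only in the orientation of the thiophene ring, and in this assay compound 2 gives 13900 nM. The change between them is thiophen-3-yl in place of thiophen-2-yl on an aromatic carbon, and it made a large step: a 32-fold lower number from compound 2 to compound 1 (1.51 log units; beyond the scatter).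

Compound 3, `CNc1ncnc2c1c(-c1cccs1)cn2[C@@H]1O[C@H](CO)[C@@H](O)[C@H]1O`, keeps the thiophen-2-yl group of compound 2 but changes the group on the six-membered ring: methylamino in place of methoxy on an aromatic carbon. For compound 3 this assay gives only a limit, > 20000 nM, which is the limit of > 20000 nM in this assay, at which 1 of the 3 values shown sits. The step of an at least 1.4-fold higher number from compound 2 to compound 3 (0.15 log units; that floor lies within the scatter) therefore sets a floor rather than a number.

Compound 4, `CNc1ncnc2c1c(-c1ccsc1)cn2[C@@H]1O[C@H](CO)[C@@H](O)[C@H]1O`, has not yet been measured. It stands to compound 3 exactly as compound 1 stands to compound 2: thiophen-3-yl in place of thiophen-2-yl on an aromatic carbon. The surroundings of the change are the same in both pairs word for word, so this is the same change made a second time, on a core that differs by methylamino in place of methoxy on an aromatic carbon. Taking the step from compound 2 to compound 1 as the guide, the expected step from compound 3 to compound 4 is an at least 13-fold lower number from compound 3 to compound 4 (1.12 log units; beyond the scatter), a large drop of the same kind but starting from a limit, so the starting point is uncertain. On that basis compound 4 is expected to give about 1500 nM in this assay, with a likely range from 300 nM to 8000 nM.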

Compound 4, half-maximal inhibitory concentration: > 20000 nM
Compound 4 ended at the assay's limit (the forecaster's own chance of this, stated with the estimate: 15%); middle value at least 13-fold (1.12 log units) away from the limit.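

In this assay compound 4 gives only a limit, > 20000 nM, not a number, and the series now has a second compound at that limit: the limit of > 20000 nM in this assay, at which 2 of the 4 values shown sit.

Compound 3 and compound 4 both stand at a limit, so the step between them cannot be read; thiophen-3-yl in place of thiophen-2-yl gave a 32-fold lower number from compound 2 to compound 1 (1.51 log units; beyond the scatter) on the methoxy core, but on the methylamino core it left the read-out at the limit, which shows that the change did not carry over far enough to give a measurable number and does not show whether it had any smaller effect there. Methylamino in place of methoxy, the other change in this set, gives an at least 46-fold higher number from compound 1 to compound 4 (1.66 log units; beyond the scatter), yet that step cannot be set firmly against the same change made with thiophen-2-yl in place: the same change on two cores in this assay, an at least 1.4-fold higher number (0.15 log units; that floor lies within the scatter) from compound 2 to compound 3 and an at least 46-fold higher number (1.66 log units; beyond the scatter) from compound 1 to compound 4; the limit leaves it open whether they differ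

The compounds shown leave open how thiophen-3-yl would behave with other groups in the place of methoxy, such as ethoxy, a plain amino group or dimethylamino. They also leave open whether other rings in the place of the thiophene, such as phenyl or furan-3-yl, would respond to methoxy and methylamino in the same way.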